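A few compounds are considered here, and "the series" means these few. Any claim that something is new, unique, unknown or untested is made for them only; others in the source may bear on it.

Compound 1 `O=C1COCCN1c1ccc(/N=C\c2cn(C(=O)c3ccccc3)c3ccccc23)cc1` and compound 2 `O=C1COCCN1c1ccc(/N=C\c2cn(C(=O)c3ccc(Cl)cc3)c3ccccc23)cc1` share one core and differ only by a single chloro group. In an ADME assay on BV-2 cells (Mus musculus) for cytotoxicity, read by MTT assay, with a stated time of 48 h, tested at 60 uM (on this read-out lower numbers stand for a stronger effect and higher numbers for a weaker effect at the one concentration tested), compound 1 gives 57.5%, while compound 2 gives 84.2%. Between the two, a number 26.7 percentage points higher from compound 1 to compound 2 (beyond the scatter), and compound 2 therefore stands highest of the two numbers measured, which here means the weaker effect on the cells. Compound 3 `O=C1COCCN1c1ccc(/N=C\c2cn(Cc3ccc(F)cc3)c3ccccc23)cc1` is the next step from compound 2: 4-fluorobenzyl in place of (4-chlorophenyl)carbonyl on an aromatic nitrogen. Among the measured compounds shown here, no measured step covers this kind of exchange. For the measured compounds named here, the single step measured shows that adding a halogen to the ring raised the number by a modest amount, but in the new step the halogen changes and the carbonyl is lost, so that step offers only weak guidance. A change of uncertain direction, near or within the scatter, is therefore expected. Compound 3 is estimated to give 76%, within the range 52% to 96%. That estimate means an expected step of a number 8.2 percentage points lower from compound 2 to compound 3 (within the scatter).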

Compound 3, a percentage reported as activity, at one concentration (the size of the read-out at that concentration, not a potency): 67.4%
For compound 3 the middle estimate is 8.6 percentage points above the measured one; the range from low to high includes it.
By their numbers in this assay, from the lowest: compounds 1 and 3 (each within the scatter of the next); then compound 2.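

Exchanging the whole group on the aromatic nitrogen, not just a substituent on its ring, also moves the read-out: in this assay replacing (4-chlorophenyl)carbonyl with 4-fluorobenzyl gives a number 16.8 percentage points lower from compound 2 to compound 3 (beyond the scatter) and so a stronger effect on the cells. Replacing benzoyl with 4-fluorobenzyl gives a number 9.9 percentage points higher from compound 1 to compound 3 (within the scatter) and so does not separate these two groups, which leaves compound 2 alone at the weak-effect end of this small set. Nothing available explains these differences.

As far as these compounds go, the exchange from compound 2 to compound 3 swaps chloro for fluoro and removes the carbonyl in one move, so the share of each in the result stays open. Also open, from the compounds shown here alone, is how a different group on this nitrogen, such as a longer alkyl chain, an amine or a carboxylic acid, would behave in this assay on these cells.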